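The compounds below may be only part of what the source reports. "The series", "measured", "known", "first", "only" and "open" are said of these compounds alone.

Compound 1 `Cn1cnc(C(=O)NNC(=O)COc2ccc(C(=O)c3ccccc3)cc2)c1` and compound 3 `O=C(COc1ccc(C(=O)c2ccccc2)cc1)NNC(=O)c1ccc(=O)oc1` are built on the same core and differ in one place only, on a carbonyl carbon whose other neighbours are an amide-type nitrogen: a group of 7 heavy atoms (5 carbon, 2 oxygen; one six-membered aromatic ring with 1 hetero atom) in place of a group of 6 heavy atoms (4 carbon, 2 nitrogen; one five-membered aromatic ring with 2 hetero atoms), on a carbonyl carbon. In a functional assay on A549 cells (Homo sapiens) for cytotoxicity, read by LDH release, with a stated time of 48 h (on this read-out lower numbers stand for stronger inhibition and higher numbers for weaker inhibition), compound 1 gives 31600 nM. In the same assay compound 3 gives 90900 nM. The change from the first to the second is summed up as a 2.9-fold higher number from compound 1 to compound 3 (0.46 log units; beyond the scatter).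

Compound 2 `Cn1cnc(C(=O)NNC(=O)COc2c(F)cc(C(=O)c3ccc(Cl)cc3)cc2Cl)c1` carries a different core; how that core differs from the core of compound 1 is not broken down here. In this assay compound 2 gives 45800 nM. Its value and that of compound 1 lie within the usual scatter of each other, as do its value and that of compound 3, so no order among these three can be drawn from those two comparisons alone.

Compound 4 `O=C(COc1c(F)cc(C(=O)c2ccc(Cl)cc2)cc1Cl)NNC(=O)c1ccc(=O)oc1` has not been measured. It relates to compound 2 exactly as compound 3 relates to compound 1: a group of 7 heavy atoms (5 carbon, 2 oxygen; one six-membered aromatic ring with 1 hetero atom) in place of a group of 6 heavy atoms (4 carbon, 2 nitrogen; one five-membered aromatic ring with 2 hetero atoms), on a carbonyl carbon. The place is described in the same words in both cases, so this is the same change, now made on the core of compound 2.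

Going by the values given here, because a 2.9-fold higher number from compound 1 to compound 3 (0.46 log units; beyond the scatter) was the only measured instance of this change and lay beyond the scatter, compound 4 is expected to shift by about a 2.6-fold higher number from compound 2 to compound 4 (0.42 log units; beyond the scatter). For compound 4 the estimated value in this assay is 120000 nM, expected to fall between 50000 nM and 300000 nM. Such a weak value may come back only as a limit of the assay.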

Compound 4, half-maximal inhibitory concentration: 84900 nM
The estimate for compound 4 lay 1.4-fold (0.15 log units) above the measured number; the measured number falls inside the stated range.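

In this assay, putting the six-membered aromatic ring with 1 hetero atom in place of 1-methyl-1H-imidazol-4-yl on the core of compound 2 gives a 1.9-fold higher number from compound 2 to compound 4 (0.27 log units; within the scatter), so this step taken alone cannot be told apart from the scatter of repeated measurements. Set beside the step on the core of compound 1, it shows no measurable difference between the two cores in the size of the change: the same change on two cores in this assay, a 2.9-fold higher number (0.46 log units; beyond the scatter) from compound 1 to compound 3 and a 1.9-fold higher number (0.27 log units; within the scatter) from compound 2 to compound 4, 1.6-fold (0.19 log units) apart, within the scatter of two such steps. This makes the result on one core a fair guide to the result on the other within this pair of cores, but it does not show that the size of the change is truly the same, nor that the change has a firm effect on the core of compound 2, and two pairs in one assay establish no rule for the series.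

The compounds shown leave open how this change would behave on cores other than these two, and whether it would behave alike in any read-out other than this assay. They also leave open what a phenyl ring, a pyridine ring, an amine or a carboxylic acid would give on the same carbonyl carbon.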